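The source may report more compounds than this note shows. Statements on the series, on what has been measured and on what is new or still open speak of the compounds shown alone.

Compound 1, `COc1ccc(-c2nc(CN)sc2-c2ccc(OC)cc2)cc1`: > 100 nM
Compound 2, `COc1ccc(-c2nc(CNC(=O)CSC)sc2-c2ccc(OC)cc2)cc1`: < 100 nM

In a functional assay with Oryctolagus cuniculus as the target (a lower number here means a stronger inhibitor, a higher number a weaker inhibitor), compound 1 gives > 100 nM, which is a limit of the assay and not a number. In this assay compound 2 gives < 100 nM, again a limit rather than a measured number. Compound 2 therefore stands at the stronger of the two limits shown, and how far past that limit it really lies is unknown. For the measured compounds named here, the only measured step, a number no higher from compound 1 to compound 2 (the limit leaves the size open), tells that ((methylsulfanyl)methyl)carbonyl in place of hydrogen on the amine nitrogen did not weaken inhibition; its size cannot be read because both ends are limits the limit of < 100 nM in this assay, at which 1 of the 2 values shown sits (the limit of > 100 nM in this assay, at which 1 of the 2 values shown sits).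

Compound 3 is `COc1ccc(-c2nc(C(=O)N3CCCCC3)sc2-c2ccc(OC)cc2)cc1`. The change from compound 2 is (piperidin-1-yl)carbonyl in place of ((((methylsulfanyl)methyl)carbonyl)amino)methyl on an aromatic carbon. This removes the whole side chain that the measured step built up and puts a carbonyl group carrying a ring directly on the aromatic carbon, so that step bears on it only loosely and gives no direction. Compound 3 is therefore expected near the limit where compound 2 sits, at about 150 nM, with a wide range from 30 nM to 800 nM. This estimate means a step of an at least 1.5-fold higher number from compound 2 to compound 3 (0.17 log units; that floor lies within the scatter), with no direction beyond the scatter to be trusted.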

Compound 3, half-maximal inhibitory concentration: > 1000 nM
Compound 3 gave a limit, no number; the forecaster's own chance of this, stated with the estimate: 45%; middle value at least 6.6-fold (0.82 log units) away from the limit.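

In this assay, (piperidin-1-yl)carbonyl in place of ((((methylsulfanyl)methyl)carbonyl)amino)methyl on the ring carbon gives an at least 10-fold higher number from compound 2 to compound 3 (1.00 log units; beyond the scatter), which shows that inhibition depends on the group at this position and does not survive every replacement there. Going by these compounds, the exchange removes the one hydrogen-bond donor of the leaving group and brings in a six-membered non-aromatic ring, while the two 4-methoxyphenyl groups stay the same, so the loss of inhibition traces to this one place even though its size remains open, and compound 3 gives only a limit, not a number: the limit of > 1000 nM in this assay, at which 1 of the 3 values shown sits. The step from compound 1 to compound 3 cannot be read, as both of its ends are limits.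

This single exchange alters several features at once, so the compounds shown do not separate the role of the amide hydrogen, the methylene link to the ring, the sulfur or the piperidine ring. A plain dimethylamino carbonyl group, or a longer chain ending in a carboxylic acid at the same carbon, would help to show which of these features matters.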